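Trading a Methoxy for a Hydroxy

The compounds below may be only part of what the source reports. "The series", "measured", "known", "first", "only" and "open" are said of these compounds alone.

In a functional assay on KB cells (Homo sapiens) for cytotoxicity, read by colorimetric assay (a lower number here means a stronger inhibitor, a higher number a weaker inhibitor), two related compounds have been measured so far. Compound 1 `COc1cc2c(cc1O)CC[C@@H](c1ccc(O)c(O)c1)O2` gives 24600 nM, and compound 2 `COc1cc([C@@H]2CCc3cc(OC)c(OC)cc3O2)ccc1O` gives 106000 nM. Compound 2 therefore holds the higher number of the pair, which makes it the weaker inhibitor, and the gap between the two lies beyond the usual scatter of repeated measurements.

Compound 3 `COc1cc2c(cc1OC)O[C@H](c1ccc(O)c(O)c1)CC2` has not yet been measured. It differs from compound 2 by one small edit: hydrogen in place of methyl on an oxygen on an aromatic ring, so a methoxy becomes a hydroxy. Within the data shown here, no measured pair shows this edit on its own, so its size in this assay can only be judged indirectly. Among the measured compounds shown here, the one measured comparison, compound 1 at 24600 nM, lies lower, so a fall in the number seems more likely than a rise. The estimated change, a 2.4-fold lower number from compound 2 to compound 3 (0.37 log units; beyond the scatter), is expected to be a modest one in that direction. For compound 3 the expected value is 45000 nM, with an estimated range from 15000 nM to 120000 nM.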

Compound 3, half-maximal inhibitory concentration: 43100 nM
For compound 3 the middle estimate is 1.0-fold (0.02 log units) above the measured one, and the stated range covers the measured number.
By their numbers in this assay, from the lowest: compounds 1 and 3 (each within the scatter of the next); then compound 2.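

Among these compounds, the first direct reading of a methoxy becoming a hydroxy at this oxygen on an aromatic ring is a 2.5-fold lower number from compound 2 to compound 3 (0.39 log units; beyond the scatter) in this assay, so removing that one methyl carbon is enough to shift the number measurably. The same kind of edit at a different oxygen of the shared core, read in the other direction as methyl in place of hydrogen, gives a 1.8-fold higher number from compound 1 to compound 3 (0.24 log units; within the scatter) and so stays within the scatter, which means these two oxygens cannot be treated as interchangeable in this small set, although each step rests on a single pair of compounds. No measurement available here offers a reason for this difference between the two oxygens.

Still open, from the compounds shown here alone, is what this oxygen would do with a longer chain such as ethoxy, or whether an amine in place of the hydroxy would give a number like that of compound 3. It is also unknown whether the step from methoxy to hydroxy would keep its size on a different core, or when the other oxygens of the shared core are changed.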